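Alkyl-to-aryl swap at the aminopyrimidine nitrogen

This account rests on a few compounds, and the source may have more. Where it says the series, first, only, none or still open, it means among the compounds named here.

Measured so far:
- compound 1 `O=C(Nc1ccc(Nc2nccc(NC3CCCCC3)n2)cc1)Nc1ccc(Cl)c(C(F)(F)F)c1` gives 7430 nM in a functional assay on A549 cells (Homo sapiens) for antiproliferative activity, read by MTT assay, with a stated time of 72 h; on this read-out higher numbers stand for weaker inhibition and lower numbers for stronger inhibition
- compound 2 `O=C(Nc1ccc(Nc2nccc(NC3CCCC3)n2)cc1)Nc1ccc(Cl)c(C(F)(F)F)c1` gives 5880 nM in this assay
- compound 3 `CCCNc1ccnc(Nc2ccc(NC(=O)Nc3ccc(Cl)c(C(F)(F)F)c3)cc2)n1` gives 7320 nM in this assay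

Compound 3 sits second highest of the three numbers, yet every gap to its neighbours is within the scatter: a 1.0-fold lower number from compound 1 to compound 3 (0.01 log units; within the scatter) and a 1.2-fold higher number from compound 2 to compound 3 (0.10 log units; within the scatter) show that cyclohexyl, cyclopentyl and propyl on this nitrogen are indistinguishable here. Compound 4 `O=C(Nc1ccc(Nc2nccc(Nc3cccc(Cl)c3)n2)cc1)Nc1ccc(Cl)c(C(F)(F)F)c1` makes a larger change: 3-chlorophenyl in place of propyl on a nitrogen on an aromatic ring. Within the data shown here, no measured step exchanges an alkyl group for an aromatic ring at this position, so the three steps give no direct guide; they only suggest the site tolerates variation without a shift beyond the scatter. Compound 4 is therefore expected to stay near compound 3, with a 1.2-fold lower number from compound 3 to compound 4 (0.09 log units; within the scatter) as the estimated step and a wide range, giving 6000 nM between 1500 nM and 20000 nM.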

Compound 4, half-maximal inhibitory concentration: 8050 nM
Compound 4: the middle estimate sits 1.3-fold (0.13 log units) below what was measured; the measured number falls inside the stated range.
By their numbers in this assay, from the lowest: compounds 2, 3, 1 and 4 (each within the scatter of the next).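

Exchanging an alkyl group for an aromatic ring on this nitrogen leaves this assay without a shift beyond the scatter, with a 1.1-fold higher number from compound 3 to compound 4 (0.04 log units; within the scatter) and a 1.4-fold higher number from compound 2 to compound 4 (0.14 log units; within the scatter) and a 1.1-fold higher number from compound 1 to compound 4 (0.03 log units; within the scatter). The site therefore accepts 3-chlorophenyl as well as all three alkyl groups, so this change does not separate the compounds. No measurement shown accounts for this flat result.

Still open, on these data alone, is whether any group here can shift the number. A chain ending in an amine or a carboxylic acid would test that.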